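The source may hold more compounds than are shown below. What is called first, only, known or untested is meant among the compounds shown, and "the series" means these compounds.

Measured in an ADME assay on microsomes from liver (Homo sapiens) for metabolic stability, with a stated time of 10 min; a lower number here means that less of the compound is left, a higher number that more of the compound is left:
compound 1, `CC[C@]1(C(=O)O)CC[C@H](C(=O)N2CC[C@](c3ccc(C(F)(C(F)(F)F)C(F)(F)F)cc3)(S(=O)(=O)c3ccc(F)cc3)C2)CC1`: 100%
compound 2, `CO[C@]1(C(=O)N2CC[C@](c3ccc(C(F)(C(F)(F)F)C(F)(F)F)cc3)(S(=O)(=O)c3ccc(F)cc3)C2)CC[C@H](C(=O)O)CC1`: 82%
compound 3, `COC[C@]1(C(=O)N2CC[C@](c3ccc(C(F)(C(F)(F)F)C(F)(F)F)cc3)(S(=O)(=O)c3ccc(F)cc3)C2)CC[C@H](C(=O)O)CC1`: 100%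

Compound 3 stands level with compound 1 at the digits shown, the two together the highest of the three numbers; no change at the digits printed from compound 1 to compound 3 (within the scatter) is within the scatter, while compound 2 sits lowest, with a number 18 percentage points higher from compound 2 to compound 3 (beyond the scatter) beyond the scatter, as is a number 18 percentage points lower from compound 1 to compound 2 (beyond the scatter).

Compound 4, `O=C([C@H]1CC[C@H](c2nnn[nH]2)CC1)N1CC[C@](c2ccc(C(F)(C(F)(F)F)C(F)(F)F)cc2)(S(=O)(=O)c2ccc(F)cc2)C1`, has not been measured in this assay. The change from compound 3: 4-(1H-tetrazol-5-yl)cyclohexyl in place of 4-carboxy-1-(methoxymethyl)cyclohexyl on a carbonyl carbon. None of the three measured steps bears directly on this change: each of them exchanges a substituent on a saturated ring carbon while the 4-carboxy group stays, whereas here the whole 4-carboxy-1-(methoxymethyl)cyclohexyl leaves. Among the measured compounds shown here, compound 3 already stands at the top of the read-out, so no step upward is possible; a modest drop or no change beyond the scatter both remain plausible. Compound 4 is therefore expected to give 90%, between 70% and 100%, an expected step of a number 10 percentage points lower from compound 3 to compound 4 (within the scatter).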

Compound 4, percent of the compound remaining: 100%
Estimate against measurement, compound 4: 10 percentage points below; the measured number falls inside the stated range.
By their numbers in this assay, from the lowest: compound 2; then compounds 1, 3 and 4 (each within the scatter of the next).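

In this assay the whole group on the carbonyl carbon can be exchanged with no visible loss: 4-(1H-tetrazol-5-yl)cyclohexyl in place of 4-carboxy-1-(methoxymethyl)cyclohexyl gives no change at the digits printed from compound 3 to compound 4 (within the scatter) and in place of 4-carboxy-4-ethylcyclohexyl gives no change at the digits printed from compound 1 to compound 4 (within the scatter) so, among these compounds, neither the 4-carboxy group nor a further substituent on the saturated ring carbon is needed to keep the read-out at the top. The same group in place of 4-carboxy-1-methoxycyclohexyl gives a number 18 percentage points higher from compound 2 to compound 4 (beyond the scatter) and compound 2 remains the only one of the four set apart from the others. Nothing at hand accounts for this difference.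

This exchange alters the acid group and the ring substituent at once, so their separate contributions stay unresolved, and three compounds sharing the top of the read-out cannot be ranked in this assay. Open too, going by these compounds, is how the plain 4-carboxycyclohexyl, with its carboxylic acid and no further ring substituent, or an amine in place of the tetrazole would behave at this position.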